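Chloro in Place of Fluoro on the Benzamide of Compound 3

The source may hold more compounds than are shown below. What is called first, only, known or untested is meant among the compounds shown, and "the series" means these compounds.

Within the data shown here, compound 3 `CCC(=O)N1CCc2cc(CNC(=O)c3cccc(F)c3)ccc21` is one of three compounds measured in an assay on HEK293 cells for inhibition of Indoleamine 2,3-dioxygenase 1 (Homo sapiens), tested at 10 uM; a higher number here means more inhibition at the concentration tested (going by the name of the read-out), a lower number less inhibition. In this assay compound 3 gives 82%. Compound 1 `CC(C)CC(=O)N1CCc2cc(CNC(=O)c3cccnc3)ccc21` gives 86% in this assay, and compound 2 `CCC(=O)N1CCc2cc(CNC(=O)c3cccs3)ccc21` gives 89% in this assay; all three numbers lie within the usual scatter of one another, so compound 3 stands level with the others. Among the measured compounds shown here, the only measured step touching this part of the structure is a number 7 percentage points lower from compound 2 to compound 3 (within the scatter), which itself stays within the scatter. Compound 4 `CCC(=O)N1CCc2cc(CNC(=O)c3cccc(Cl)c3)ccc21` differs from compound 3 by chloro in place of fluoro on an aromatic carbon. For the measured compounds named here, no measured step shows how chloro compares with fluoro here, so no change beyond the scatter is expected. The estimate for compound 4 in this assay is 83%, between 70% and 93%. The expected step is therefore a number 1 percentage points higher from compound 3 to compound 4 (within the scatter).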

Compound 4, a percentage reported as inhibition, at one concentration (the size of the read-out at that concentration, not a potency): 77%
Compound 4: the middle estimate sits 6 percentage points above what was measured; measured number inside the range.
By their numbers in this assay, from the lowest: compounds 4, 3, 1 and 2 (each within the scatter of the next, the first and the last beyond it).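

In this assay, chloro in place of fluoro on this aromatic carbon gives a number 5 percentage points lower from compound 3 to compound 4 (within the scatter), so the two groups cannot be told apart here. The 3-chlorophenyl group does, however, bring the first modest gap beyond the scatter among the groups on this carbonyl carbon, a number 12 percentage points lower from compound 2 to compound 4 (beyond the scatter), whereas the 3-fluorophenyl step from thiophen-2-yl stayed within it. No supporting information bears on this gap.

The compounds shown leave open how a methoxy or a trifluoromethyl group on the same aromatic carbon would compare with fluoro and chloro. They also leave open whether an amine there would keep the reading level.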